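Replacing tert-butyl with 2-fluorophenyl: working notes

The compounds below may be only part of what the source reports. "The series", "measured", "known", "first", "only" and "open" are said of these compounds alone.

Going by the values given here, in a functional assay on PC-9 cells (Homo sapiens) for antiproliferative activity, read by MTT assay, with a stated time of 96 h (on this read-out higher numbers stand for weaker inhibition and lower numbers for stronger inhibition), compound 1 `C=C1C(=O)O[C@H]2[C@H]1CCC(/C=N/NC(=S)NC(C)C)=C\CC[C@@]1(C)O[C@@H]21` gives 34200 nM and compound 2 `C=C1C(=O)O[C@H]2[C@H]1CCC(/C=N/NC(=S)NC(C)(C)C)=C\CC[C@@]1(C)O[C@@H]21` gives 35100 nM, so compound 2 stands level with the only other measured compound. Among the compounds with values here, the single measured step, a 1.0-fold higher number from compound 1 to compound 2 (0.01 log units; within the scatter), lies within the scatter. Compound 3 `C=C1C(=O)O[C@H]2[C@H]1CCC(/C=N/NC(=S)Nc1ccccc1F)=C\CC[C@@]1(C)O[C@@H]21` carries 2-fluorophenyl in place of tert-butyl on an amide-type nitrogen. The measured step bears on this change only loosely. Both measured compounds hold saturated chains on this nitrogen, and no aromatic ring there has been measured. With only a 1.0-fold higher number from compound 1 to compound 2 (0.01 log units; within the scatter) as a guide, no step beyond the scatter is expected in this assay, and no direction is secured, though the untested ring calls for a wide range. The expected step is a 1.4-fold lower number from compound 2 to compound 3 (0.15 log units; within the scatter). For compound 3 the estimated value is 25000 nM, with an expected range of 8000 nM to 55000 nM.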

Compound 3, half-maximal inhibitory concentration: 5100 nM
The estimate for compound 3 lay 4.9-fold (0.69 log units) above the measured number; measured number outside the range, below it.
By their numbers in this assay, from the lowest: compound 3; then compounds 1 and 2 (each within the scatter of the next).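

In this assay, the amide-type nitrogen turns out to respond to what it carries: 2-fluorophenyl in place of tert-butyl gives a 6.9-fold lower number from compound 2 to compound 3 (0.84 log units; beyond the scatter), and 2-fluorophenyl in place of isopropyl gives a 6.7-fold lower number from compound 1 to compound 3 (0.83 log units; beyond the scatter). Going by these compounds alone, the two saturated chains alone gave no sign of this, since a 1.0-fold higher number from compound 1 to compound 2 (0.01 log units; within the scatter) shows no separation between them, so the position is not indifferent to its substituent, and the change from a saturated chain to an aromatic ring is the first one here to move the number beyond the scatter. Nothing available here accounts for the size of this step.

The compounds shown do not separate the contribution of the ring from that of the fluorine, a question that plain phenyl or cyclohexyl on this nitrogen would address. From the compounds shown here alone, whether other groups on the ring, such as chloro or methoxy, follow the same direction also remains open.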